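Swapping a Naphthyl Group for Dimethylaminophenyl on a Pyridine Core

The compounds below may be only part of what the source reports. "The series", "measured", "known", "first", "only" and "open" are said of these compounds alone.

Of the compounds shown here, three sharing one core have been tested in a functional assay on aorta (strain Wistar) for inhibition, with Thoracic aorta (Rattus norvegicus) as the target; on this read-out higher numbers stand for weaker inhibition and lower numbers for stronger inhibition. Compound 1 `COc1nc(-c2cc3ccccc3o2)cc(-c2cccc3ccccc23)c1C#N` gives 359000 nM. Compound 2 `CCOc1nc(-c2cc3ccccc3o2)cc(-c2cccc3ccccc23)c1C#N` gives 344000 nM, and compound 3 `CCOc1nc(-c2cc3ccccc3o2)cc(-c2cc(OC)c(OC)c(OC)c2)c1C#N` gives 365000 nM. Within the data shown here, the single step between measured compounds, a 1.0-fold lower number from compound 1 to compound 2 (0.02 log units; within the scatter), shows that lengthening the ether chain changed nothing beyond the scatter. Compound 2 stands with a number that lies within the usual scatter of both compound 1 and compound 3, so the three are indistinguishable on this read-out.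

Compound 4 `CCOc1nc(-c2cc3ccccc3o2)cc(-c2ccc(N(C)C)cc2)c1C#N` is not yet measured. It differs from compound 2 in one place: 4-(dimethylamino)phenyl in place of naphthalen-1-yl on an aromatic carbon. Among the measured compounds shown here, no measured step involves this position directly; compound 2 and compound 3, which differ there, show only numbers within the scatter of each other. Given that, compound 4 is expected to give a number close to that of compound 2, with a step of a 1.0-fold higher number from compound 2 to compound 4 (0.01 log units; within the scatter). The estimate for compound 4 in this assay is 350000 nM, within a range of 150000 nM to 800000 nM.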

Compound 4, half-maximal inhibitory concentration: 338000 nM
Compound 4: the middle estimate sits 1.0-fold (0.02 log units) above what was measured; low and high end bracket the measured number.
By their numbers in this assay, from the lowest: compounds 4, 2, 1 and 3 (each within the scatter of the next).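

Among these compounds, replacing naphthalen-1-yl with 4-(dimethylamino)phenyl in this assay gives a 1.0-fold lower number from compound 2 to compound 4 (0.01 log units; within the scatter), the first direct reading of a change at this position with everything else on the shared core held the same. On this read-out, a group with two six-membered aromatic rings of carbon and a group with one such ring plus a dimethylamino nitrogen, which adds a hydrogen-bond acceptor, cannot be told apart. No independent measurement is available to explain this lack of difference.

On these data alone, whether a group such as a carboxylic acid or a primary amine at this position would give a number beyond the scatter remains open. So does whether replacing the 1-benzofuran-2-yl group or the nitrile elsewhere on the core would shift the number.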